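Cyanoguanidine in place of phenylthiourea on the shared core

This account rests on a few compounds, and the source may have more. Where it says the series, first, only, none or still open, it means among the compounds named here.

Working notes on the series. Compound 1 `N#CNC(=N)NCCCCCn1nc(-c2ccccc2)ccc1=O`, compound 2 `CC(C)(C)/N=C(\S)NCCCCn1nc(-c2ccccc2)ccc1=O` and compound 3 `O=c1ccc(-c2ccccc2)nn1CCCCNC(=S)Nc1ccccc1` share one core and differ only in the group carried on the saturated chain. In a functional assay on the whole organism (stomach) with Rattus norvegicus as the target (a lower number here means that less compound is needed, a higher number that more compound is needed for the effect), compound 1 gives > 100 mg/kg, which is a limit of the assay and not a number. Compound 2 gives > 100 mg/kg in this assay, again only a limit. Compound 3 stands at > 100 mg/kg in this assay, likewise a limit. The step that the two limits leave unreadable from compound 1 to compound 2 and the step that the two limits leave unreadable from compound 2 to compound 3 therefore cannot be read in size or direction. All values shown fall under (the limit of > 100 mg/kg in this assay, at which 3 of the 3 values shown sit).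

Compound 4 `N#CNC(=N)NCCCCn1nc(-c2ccccc2)ccc1=O` differs from compound 3 by a group of 5 heavy atoms (2 carbon, 3 nitrogen; no ring) in place of a group of 9 heavy atoms (7 carbon, 1 nitrogen, 1 sulfur; one six-membered aromatic ring of carbon only), on an amine nitrogen. Both measured steps bear on this change, each swapping the terminal group on the same chain, yet neither yields a readable size. Compound 1, which carries the same entering group, also gives only a limit in this assay. Compound 4 is therefore expected to give 150 mg/kg, with a range from 60 mg/kg to 400 mg/kg. The step that the limit leaves unreadable from compound 3 to compound 4 is expected to stay within the scatter, most likely with only a limit reported again.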

Compound 4, dose for half-maximal effect: 77.2 mg/kg
For compound 4 the middle estimate is 1.9-fold (0.29 log units) above the measured one, within the range that was stated.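

Compound 4 is the only compound shown that gives a number rather than a limit in this assay: the limit of > 100 mg/kg in this assay, at which 3 of the 4 values shown sit.

Exchanging the terminal group on the amine nitrogen for the cyanoguanidine reads as an at least 1.2-fold lower number from compound 3 to compound 4 (0.11 log units; that floor lies within the scatter) and as an at least 1.2-fold lower number from compound 2 to compound 4 (0.11 log units; that floor lies within the scatter). With the cyanoguanidine kept, the shorter chain reads as an at least 1.2-fold lower number from compound 1 to compound 4 (0.11 log units; that floor lies within the scatter), so all three steps are floors, and none is shown to go beyond the scatter.

Going by these compounds, the steps among compound 1, compound 2 and compound 3 still cannot be read, and the full size of the three new steps remains unknown. Also open, on these data alone, is how a still shorter chain, or a primary amine or urea at the chain end, would read in this assay.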